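The compounds below may be only part of what the source reports. "The series", "measured", "known", "first", "only" and "open" are said of these compounds alone.

Series notes. The shared core of compound 1 `CN(C)CCn1cnnc1-c1cc(Oc2ccc(NC(=O)N/N=C/c3cccc(Br)c3)cc2F)ccn1` carries a changing aryl on a carbon with a double bond to nitrogen. In a functional assay on A549 cells (Homo sapiens) for cytotoxicity, read by MTT assay, with a stated time of 72 h (a lower number here means a stronger inhibitor, a higher number a weaker inhibitor), compound 1 gives 970 nM. Compound 2 `CN(C)CCn1cnnc1-c1cc(Oc2ccc(NC(=O)N/N=C/c3ccccc3O[N+](=O)[O-])cc2F)ccn1` gives 1200 nM, and compound 3 `Cc1cc(/C=N/NC(=O)Nc2ccc(Oc3ccnc(-c4nncn4CCN(C)C)c3)c(F)c2)cc(C)c1O` gives 1640 nM. Compound 3 holds the highest number of the three, yet every step among them is within the scatter: a 1.2-fold higher number from compound 1 to compound 2 (0.09 log units; within the scatter), a 1.7-fold higher number from compound 1 to compound 3 (0.23 log units; within the scatter), a 1.4-fold higher number from compound 2 to compound 3 (0.14 log units; within the scatter). Compound 4 `COc1cc(/C=N/NC(=O)Nc2ccc(Oc3ccnc(-c4nncn4CCN(C)C)c3)c(F)c2)cc(OC)c1OC` differs from compound 3 at the same site: 3,4,5-trimethoxyphenyl in place of 4-hydroxy-3,5-dimethylphenyl on a carbon with a double bond to nitrogen. All three measured steps bear on it: each swaps the aryl on that carbon, and none moved the number beyond the scatter. A change at this site is therefore expected to leave compound 4 near compound 3, with no step beyond the scatter. The expected step from compound 3 to compound 4 is a 1.1-fold higher number from compound 3 to compound 4 (0.04 log units; within the scatter). For compound 4 the estimate is 1800 nM, with a range from 800 nM to 4000 nM.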

Compound 4, half-maximal inhibitory concentration: > 100000 nM
Compound 4 was reported as a limit; the forecaster's own chance of this, stated with the estimate: 5%; middle value at least 55-fold (1.74 log units) from the limit.
By their numbers in this assay, from the lowest: compounds 1, 2 and 3 (each within the scatter of the next). At a limit, above all of these: compound 4.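

The site is not as forgiving as the earlier swaps suggested, since an aryl change on the carbon with a double bond to nitrogen can produce a large step: an at least 60-fold higher number from compound 3 to compound 4 (1.78 log units; beyond the scatter), an at least 83-fold higher number from compound 2 to compound 4 (1.92 log units; beyond the scatter) and an at least 100-fold higher number from compound 1 to compound 4 (2.01 log units; beyond the scatter). Compound 4 stands at a limit, not a number: the limit of > 100000 nM in this assay, at which 1 of the 4 values shown sits. The entering 3,4,5-trimethoxyphenyl has 12 heavy atoms and 0 hydrogen-bond donors, against 9 heavy atoms and 1 hydrogen-bond donor in the leaving 4-hydroxy-3,5-dimethylphenyl, and these compounds do not separate the two differences.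

Still open, from the compounds shown here alone, is whether the step needs all three methoxy groups, which a 3,5-dimethoxyphenyl or a 4-hydroxy-3,5-dimethoxyphenyl would test. Going by these compounds, how an aryl carrying an amine or a carboxylic acid behaves at this site also remains open.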